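This account rests on a few compounds, and the source may have more. Where it says the series, first, only, none or still open, it means among the compounds named here.

Compound 1 `CC1(c2ccccc2)CC(=O)C(C2CC(c3ccc(-c4ccc(Br)cc4)cc3)Cc3ccccc32)=C(O)O1`, compound 2 `CC1(c2ccccc2)CC(=O)C(C2CC(c3ccc(OCc4ccc(C(F)(F)F)cc4)cc3)Cc3ccccc32)=C(O)O1` and compound 3 `CCCC1(CCc2ccccc2)CC(=O)C(C2CC(c3ccc(-c4ccc(Br)cc4)cc3)Cc3ccccc32)=C(O)O1` have been measured. In a functional assay on A549 cells (Homo sapiens) for inhibition, with a stated time of 72 h (a higher number here means a weaker inhibitor, a lower number a stronger inhibitor), compound 1 gives 1830 nM. Compound 2 reaches only a limit of this assay, > 10000 nM. Compound 3 likewise reaches only a limit, > 10000 nM. The difference between the core of compound 1 and the core of compound 3 is not broken down here. The change (4-(trifluoromethyl)benzyl)oxy in place of 4-bromophenyl on an aromatic carbon produced an at least 5.4-fold higher number from compound 1 to compound 2 (0.73 log units; beyond the scatter). Compound 4 `CCCC1(CCc2ccccc2)CC(=O)C(C2CC(c3ccc(OCc4ccc(C(F)(F)F)cc4)cc3)Cc3ccccc32)=C(O)O1` carries the same change on the core of compound 3, namely ((4-(trifluoromethyl)benzyl)oxy in place of 4-bromophenyl on an aromatic carbon). Since compound 3 already sits at the limit of > 10000 nM in this assay, at which 2 of the 3 values shown sit, compound 4 is expected to remain at or beyond that limit, an expected step that the limit leaves unreadable from compound 3 to compound 4. Compound 4 is therefore estimated at 30000 nM in this assay, expected to lie between 10000 nM and 100000 nM.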

Compound 4, half-maximal inhibitory concentration: > 10000 nM
Compound 4 gave a limit, no number; the forecaster's own chance of this, stated with the estimate: 85%; the middle value lies beyond the limit too.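

No step can be read from compound 3 to compound 4 in this assay, because both compounds stand at the same limit: the limit of > 10000 nM in this assay, at which 3 of the 4 values shown sit.

The compounds shown leave open whether (4-(trifluoromethyl)benzyl)oxy in place of 4-bromophenyl changes anything on the core of compound 3.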